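The source may report more compounds than this note shows. Statements on the series, on what has been measured and on what is new or still open speak of the compounds shown alone.

Compound 1 `O=C1/C(=C/c2ccccc2)NS(=O)(=O)c2ccccc21` gives 660 nM in an assay for inhibition of alkaline phosphatase, tissue-nonspecific isozyme (Homo sapiens), read by spectrophotometry, with stated times of 10 min and 20 min; on this read-out lower numbers stand for stronger inhibition and higher numbers for weaker inhibition.
Compound 2 `COc1ccc(/C=C2\NS(=O)(=O)c3ccccc3C2=O)cc1` gives 4040 nM in this assay.

Of these two numbers, compound 1 has the lower one, so it is the stronger inhibitor on this read-out. Among the measured compounds shown here, the only measured step is a 6.1-fold higher number from compound 1 to compound 2 (0.79 log units; beyond the scatter), where a group was added to the phenyl ring. Compound 3 `O=C1/C(=C/c2cccc(Br)c2)NS(=O)(=O)c2ccccc21` carries instead (bromo in place of hydrogen on an aromatic carbon). A bromo group is not a methoxy group, so that step is only a rough guide, but it suggests that adding a group to this ring weakens inhibition. A modest weakening is expected, a 2.0-fold higher number from compound 1 to compound 3 (0.29 log units; within the scatter). Compound 3 is therefore estimated at 1300 nM, between 500 nM and 3500 nM.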

Compound 3, half-maximal inhibitory concentration: > 200000 nM
Compound 3 was reported as a limit; the forecaster's own chance of this, stated with the estimate: 3%; middle value at least 150-fold (2.18 log units) away from the limit.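

Adding one bromo, a single heavy atom, on an aromatic carbon meta to a large group gives an at least 300-fold higher number from compound 1 to compound 3 (2.48 log units; beyond the scatter), far larger than a 6.1-fold higher number from compound 1 to compound 2 (0.79 log units; beyond the scatter). For compound 3, > 200000 nM in this assay is a limit of the assay and not a number. A change of one heavy atom on this phenyl ring can therefore matter far more than the first pair alone showed.

On these data alone, it remains open whether this loss belongs to bromo itself or to this place on the ring. Also open, as far as these compounds go, is whether fluoro, a hydroxyl or an amine at the same place would keep inhibition.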